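The compounds below may be only part of what the source reports. "The series", "measured", "known", "first", "only" and "open" are said of these compounds alone.

Measured so far in a physicochemical assay for lipophilicity, read by HPLC, at pH 7.5; a lower number here means a more polar compound, a higher number a more lipophilic compound:

- compound 1 `CC[C@@H](Nc1c(C#N)c(-c2ccc(-c3cccc(C)c3)cc2)nc2cnccc12)C(N)=O`: 3
- compound 2 `CC[C@@H](Nc1c(C#N)c(-c2ccc(-c3cccc(C)c3F)cc2)nc2cnccc12)C(N)=O`: 3
- compound 3 `CC[C@@H](Nc1c(C#N)c(-c2ccc(-c3cccc(Cl)c3F)cc2)nc2cnccc12)C(N)=O`: 3.1

Compound 3 stands at 3.1, within the scatter of the other two compounds, so the three numbers do not separate. The next compound to be measured is compound 4 `CC[C@@H](Nc1c(C#N)c(-c2ccc(-c3ccc(OC)cc3)cc2)nc2cnccc12)C(N)=O`, which carries 4-methoxyphenyl in place of 3-chloro-2-fluorophenyl on an aromatic carbon.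

Going by the values given here, three measured steps bear on this change, as each alters the same terminal aromatic ring. They are no change at the digits printed from compound 1 to compound 2 (within the scatter), a number 0.10 log units higher from compound 2 to compound 3 (within the scatter) and a number 0.10 log units higher from compound 1 to compound 3 (within the scatter). All three are small and lie within the scatter. Among the compounds with values here, none of them introduces a methoxy group, however, so they show only that these particular swaps left this assay almost untouched, and they cannot fix the outcome of this larger replacement. The expected step is a number 0.20 log units lower from compound 3 to compound 4 (within the scatter), a slight downward move that would not exceed the scatter. Within the data shown here, the range is kept fairly wide, as no measured compound carries the entering group. For compound 4 the estimated value is 2.9, with an expected range from 2.6 to 3.2.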

Compound 4, distribution coefficient: 2.7
For compound 4 the middle estimate is 0.20 log units above the measured one; the range from low to high includes it.
By their numbers in this assay, from the lowest: compounds 4, 1, 2 and 3 (each within the scatter of the next, the first and the last beyond it).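

In this assay, going by these compounds alone, replacing the terminal ring gives a number 0.40 log units lower from compound 3 to compound 4 (beyond the scatter) and so yields the first step that clears the scatter, showing that this position can register a change in this read-out. That separation is limited to one pair, as the same 4-methoxyphenyl group gives a number 0.30 log units lower from compound 2 to compound 4 (within the scatter) and also a number 0.30 log units lower from compound 1 to compound 4 (within the scatter) and so does not clearly part from the compounds carrying 2-fluoro-3-methylphenyl or 3-methylphenyl. Counted on the two groups, 4-methoxyphenyl has 1 hydrogen-bond acceptor where 3-chloro-2-fluorophenyl has 0, but no measurement here accounts for the shift in this assay.

The compounds shown leave open whether this step belongs to the methoxy group itself, to its place para to a large group, or to the loss of the chloro and fluoro groups, which all differ together in this one comparison. They also leave open how a hydroxyl group, an amine or a longer ether chain at the same place on the terminal ring would read in this assay.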